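The compounds below may be only part of what the source reports. "The series", "measured", "known", "first", "only" and "open" are said of these compounds alone.

Measured compounds:
compound 1, `O=[N+]([O-])c1ccc(S(=O)(=O)Nc2cccnc2)cc1` — "not determined" (no result reported)
compound 2, `Cc1csc(NS(=O)(=O)c2ccc([N+](=O)[O-])cc2)n1` — "not determined" (no result reported)
compound 3, `Cc1cc(NS(=O)(=O)c2ccc([N+](=O)[O-])cc2)no1` — > 256000 nM

The three measured compounds share a nitrophenylsulfonamide core and differ in the group on the sulfonamide nitrogen. In an ADME assay on J774 cells (Mus musculus) for cytotoxicity, read by resazurin assay, with a stated time of 24 h (a higher number here means a weaker inhibitor, a lower number a stronger inhibitor), compound 1 has no reported result, "not determined" (no result reported). Compound 2 likewise stands at "not determined" (no result reported) in this assay. Among the measured compounds shown here, compound 3 gives only a limit in this assay, > 256000 nM, so its place on the scale is not fixed; it is the single value that sits at the limit of > 256000 nM in this assay, at which 1 of the 3 values shown sits.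

Compound 4, `Cc1cc(NS(=O)(=O)c2ccc([N+](=O)[O-])cc2)n[nH]1`, carries 5-methyl-1H-pyrazol-3-yl in place of 5-methyl-1,2-oxazol-3-yl on a sulfonamide nitrogen. For the measured compounds named here, no step between measured compounds is available to scale this change. The step that the limit leaves unreadable from compound 3 to compound 4 is expected to stay within the usual scatter, with compound 4 again likely reaching the limit. Compound 4 is therefore estimated at 300000 nM in this assay, within 100000 nM to 1000000 nM.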

Compound 4, half-maximal inhibitory concentration: > 256000 nM
Compound 4 ended at the assay's limit; the forecaster's own chance of this, stated with the estimate: 80%; the middle value does not contradict the limit.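

Among the compounds shown here, compound 3 and compound 4 both end at the limit in this assay, so no step between them can be read. None of the compounds shown gives a single number, which leaves open whether the group on the sulfonamide nitrogen shifts the value at all.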